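Aryl for methyl on the shared core and exposure

The compounds below may be only part of what the source reports. "The series", "measured", "known", "first", "only" and "open" are said of these compounds alone.

Compound 2 `Cc1c([C@H](C)Nc2nc(N)nc(N)c2C#N)c(-c2ccccc2)c(=O)n2cc(F)ccc12` gives 344 ng.h/mL in an ADME assay on the whole organism (Mus musculus, strain BALB/C), read by LC-MS, with a stated time of 24 h, at a dose of 1 mg/kg by the intravenous route (a higher number here means more compound in the circulation at the dose given, a lower number less compound in the circulation), the lowest of the three numbers recorded. Compound 3 `C[C@H](Nc1nc(N)nc(N)c1C#N)c1c(-c2ccccc2)c(=O)n2cc(F)ccc2c1C1CC1` gives 683 ng.h/mL, and compound 1 `C[C@H](Nc1nc(N)nc(N)c1C#N)c1cc(=O)n2cc(F)ccc2c1-c1cc(F)cc(F)c1` gives 903 ng.h/mL, the latter standing beyond the scatter from compound 2. The step from compound 2 to compound 3 is a 2.0-fold higher number from compound 2 to compound 3 (0.30 log units; within the scatter), a change of cyclopropyl in place of methyl on an aromatic carbon that left exposure essentially where it was.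

Compound 4 `C[C@H](Nc1nc(N)nc(N)c1C#N)c1c(-c2ccccc2)c(=O)n2cc(F)ccc2c1-c1ccc(F)cc1` differs from compound 2 by 4-fluorophenyl in place of methyl on an aromatic carbon of a six-membered aromatic ring with one nitrogen, ortho to a fused ring and ortho to a large group. Going by the values given here, the only measured step at this position, from compound 2 to compound 3, stayed within the scatter, so no step beyond the scatter is expected in this assay for compound 4. Compound 4 is therefore estimated at 500 ng.h/mL, with a range of 220 ng.h/mL to 1100 ng.h/mL, a step of a 1.5-fold higher number from compound 2 to compound 4 (0.16 log units; within the scatter) that is expected to remain within the scatter.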

Compound 4, area under the concentration-time curve: 2900 ng.h/mL
Compound 4: the middle estimate sits 5.8-fold (0.76 log units) below what was measured; the whole stated range lies below it.
By their numbers in this assay, from the lowest: compounds 2, 3 and 1 (each within the scatter of the next, the first and the last beyond it); then compound 4.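

In this assay, this aromatic carbon turns out to be a place where a change can move the number: 4-fluorophenyl in place of methyl gives an 8.4-fold higher number from compound 2 to compound 4 (0.93 log units; beyond the scatter), and 4-fluorophenyl in place of cyclopropyl gives a 4.2-fold higher number from compound 3 to compound 4 (0.63 log units; beyond the scatter). The earlier step at this position, cyclopropyl in place of methyl, stayed within the scatter, so only the entry of the 4-fluorophenyl group shows a change here reaching beyond it. No measurement at hand bears on what lies behind this rise.

On these data alone, it remains open whether an unsubstituted phenyl or a pyridyl ring at this position would give a number like that of compound 4, and so whether the fluorine has any part in the step. As far as these compounds go, how an amine or a methoxy group would fare on this carbon is equally open.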